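Swapping 2-chlorophenyl for 3-methylphenyl on the shared core

The source may report more compounds than this note shows. Statements on the series, on what has been measured and on what is new or still open speak of the compounds shown alone.

- Compound 1 `C[C@H]1CC[C@@H]2[C@@H](OC(=O)[C@]23CC(c2c(Cl)cccc2Cl)=NO3)[C@]2(C)C(=O)C=C[C@@]12O` gives 2.67
- Compound 2 `C[C@H]1CC[C@@H]2[C@@H](OC(=O)[C@]23CC(c2ccc(Cl)cc2)=NO3)[C@]2(C)C(=O)C=C[C@@]12O` gives 2.09
- Compound 3 `C[C@H]1CC[C@@H]2[C@@H](OC(=O)[C@]23CC(c2ccccc2Cl)=NO3)[C@]2(C)C(=O)C=C[C@@]12O` gives 2.09

In a physicochemical assay for lipophilicity (a lower number here means a more polar compound, a higher number a more lipophilic compound), compound 3 stands level with compound 2, the two together lowest of the three, while compound 1 stands higher at 2.67 on the same scale.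

Compound 4 `Cc1cccc(C2=NO[C@]3(C2)C(=O)O[C@@H]2[C@H]3CC[C@H](C)[C@]3(O)C=CC(=O)[C@@]23C)c1` has not yet been measured. It differs from compound 3 in one group: 3-methylphenyl in place of 2-chlorophenyl on a carbon with a double bond to nitrogen and so 3-methylphenyl stands in place of 2-chlorophenyl on a carbon with a double bond to nitrogen.

Going by the values given here, two measured steps bear on this change. One is no change at the digits printed from compound 2 to compound 3 (within the scatter) between two compounds that each carry a single chloro group, in different places. The other is a number 0.58 log units lower from compound 1 to compound 3 (beyond the scatter) where a chloro group gives way to hydrogen, a modest step. Among the compounds with values here, no measured compound carries a methyl group, so this guidance is only indirect. Like compound 2 and compound 3, compound 4 keeps one group on its phenyl ring.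

In this assay no step beyond the scatter is therefore expected, and the estimated change is a number 0.01 log units higher from compound 3 to compound 4 (within the scatter) for this swap. Compound 4 is expected at 2.1 with a range of 1.8 to 2.45 on this scale.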

Compound 4, partition coefficient: 1.86
Beside the measured number, compound 4's estimate is 0.24 log units above it; the range from low to high includes it.
By their numbers in this assay, from the lowest: compounds 4, 2 and 3 (each within the scatter of the next); then compound 1.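

The earlier compounds shown here carried only chlorophenyl groups on this carbon with a double bond to nitrogen, and 3-methylphenyl now extends the comparison to a ring with no chloro group. In this assay, the new group gives a number 0.23 log units lower from compound 3 to compound 4 (within the scatter) and a number 0.23 log units lower from compound 2 to compound 4 (within the scatter), so it stays within the scatter of both groups that carry a single chloro. The 2,6-dichlorophenyl group remains the only one that stands apart, with a number 0.81 log units lower from compound 1 to compound 4 (beyond the scatter), and nothing measured here explains these numbers.

The compounds shown leave open whether methyl and chloro would read alike at one and the same place on the phenyl ring, as the step to 3-methylphenyl changes the group and its ring place together. They also leave open how this assay would respond to a different kind of group on that ring, such as an amine, a carboxylic acid or a longer chain.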